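Pyrazole chalcone series: aryl swap on the carbonyl carbon

This account rests on a few compounds, and the source may have more. Where it says the series, first, only, none or still open, it means among the compounds named here.

Among the measured compounds shown here, compound 2 `COc1ccc(C(=O)/C=C/c2cc(-c3cc(OC)c(OC)c(OC)c3)n[nH]2)cc1` is one of two compounds so far tested in a functional assay on MDA-MB-231 cells (Homo sapiens) for cytotoxicity, read by sulforhodamine B assay, with a stated time of 48 h, tested at 0.01 uM; a lower number here means a stronger effect, a higher number a weaker effect of the compound at the concentration tested. In this assay compound 2 gives 104%, the lowest of the two numbers, with compound 1 `COc1cc(-c2cc(/C=C/C(=O)c3ccc(N)cc3)[nH]n2)cc(OC)c1OC` closest: in this assay compound 1 gives 109%. For the measured compounds named here, the only measured step, a number 5 percentage points lower from compound 1 to compound 2 (within the scatter), lies within the scatter, so neither compound can be called more active than the other, and both numbers sit near the level of untreated cells at this concentration.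

Compound 3 `COc1cc(-c2cc(/C=C/C(=O)c3ccc(F)c(F)c3)[nH]n2)cc(OC)c1OC` is the next compound, not yet measured. It differs from compound 2 by 3,4-difluorophenyl in place of 4-methoxyphenyl on a carbonyl carbon. This change sits at the same place as the measured step, the group on a carbonyl carbon, where a change from amino to methoxy on the aromatic carbon gave a number 5 percentage points lower from compound 1 to compound 2 (within the scatter), within the scatter. On that basis no step beyond the scatter is expected in this assay for compound 3, in either direction; the expected step is a number 2 percentage points lower from compound 2 to compound 3 (within the scatter). The estimate for compound 3 in this assay is 102%, expected within the range 88% to 116%.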

Compound 3, a percentage reported as activity, at one concentration (the size of the read-out at that concentration, not a potency): 94%
Compound 3: middle estimate off by 8 percentage points, on the high side; measured number inside the range.
By their numbers in this assay, from the lowest: compounds 3, 2 and 1 (each within the scatter of the next, the first and the last beyond it).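

In this assay, among the compounds shown here, the group on the carbonyl carbon now produces a step beyond the scatter for the first time: a number 15 percentage points lower from compound 1 to compound 3 (beyond the scatter), modest in size, with 3,4-difluorophenyl in place of 4-aminophenyl. The swap of 4-methoxyphenyl for 3,4-difluorophenyl gives a number 10 percentage points lower from compound 2 to compound 3 (within the scatter), so compound 2 and compound 3 cannot be told apart, and only the two ends of the order separate, with compound 2 within the scatter of both. This position can therefore move the read-out at this low concentration, though only slightly, and no measurement on hand explains the step.

Open, on these data alone, is whether a single fluorine, a chlorine, a trifluoromethyl group or a carboxylic acid on the aromatic ring at the carbonyl carbon would extend the step beyond what 3,4-difluorophenyl gives. With only one concentration shown, it also remains open whether the separation of compound 1 and compound 3 would persist, widen or vanish at higher concentrations in this assay.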